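Thiophen-2-yl in Place of 4-Methylphenyl: an Expected Value

The compounds below may be only part of what the source reports. "The series", "measured", "known", "first", "only" and "open" are said of these compounds alone.

Compound 1, `Cc1nc(N)sc1CCCN/C(N)=N/C(=O)NC(C)c1ccccc1F`: 12.3 nM
Compound 2, `Cc1ccc(C(C)NC(=O)/N=C(\N)NCCCc2sc(N)nc2C)cc1`: 22.4 nM

In a functional assay on Right cardiac atrium for agonist activity at histamine H2 receptor (Cavia porcellus), with a stated time of 30 min, in the presence of a further agent that is not named here (a higher number here means that more compound is needed for the effect, a lower number that less compound is needed), compound 2 holds the highest of the two numbers, with compound 1 its nearest neighbour. Within the data shown here, the one step measured so far, a 1.8-fold higher number from compound 1 to compound 2 (0.26 log units; within the scatter), was itself an exchange of the aromatic group at the same place. Compound 3, `Cc1nc(N)sc1CCCN/C(N)=N/C(=O)NC(C)c1cccs1`, differs from compound 2 by thiophen-2-yl in place of 4-methylphenyl on a saturated chain carbon bound to an amide-type nitrogen and a saturated chain carbon. Among the measured compounds shown here, since the only comparable step stayed within the scatter, the expected step is a 1.1-fold lower number from compound 2 to compound 3 (0.05 log units; within the scatter), none beyond the scatter. Compound 3 is therefore estimated at 20 nM, with a range from 8 nM to 50 nM.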

Compound 3, half-maximal effective concentration: 10 nM
The estimate for compound 3 lay 2.0-fold (0.30 log units) above the measured number; the range from low to high includes it.
By their numbers in this assay, from the lowest: compounds 3, 1 and 2 (each within the scatter of the next, the first and the last beyond it).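

In this assay, among these compounds, the first step beyond the scatter at this place is a 2.2-fold lower number from compound 2 to compound 3 (0.35 log units; beyond the scatter) with thiophen-2-yl entering for 4-methylphenyl, so this position accepts a five-membered aromatic ring with sulfur without any loss. Against 2-fluorophenyl the exchange gives a 1.2-fold lower number from compound 1 to compound 3 (0.09 log units; within the scatter) and does not separate the two groups. Nothing available explains the modest gain over 4-methylphenyl.

The compounds shown all carry an aromatic ring here, so it remains open whether cyclohexyl would serve as well. On these data alone, whether furan-2-yl would match thiophen-2-yl also remains open.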